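One Stereocentre Redrawn: From Compound 2 to Compound 4

The source may report more compounds than this note shows. Statements on the series, on what has been measured and on what is new or still open speak of the compounds shown alone.

Measured in an ADME assay on microsomes from liver (Mus musculus); on this read-out higher numbers stand for a more stable compound and lower numbers for a less stable compound:
- compound 1 `C[C@H]1CN(c2cc(-c3cc(C(F)(F)F)c4c(N)ncnn34)ccc2C#N)C(=O)C(C)(C)O1`: 24%
- compound 2 `C[C@@H]1CN(c2cc(-c3cc(Cl)c4c(N)ncnn34)ccc2C#N)C(=O)C(C)(C)O1`: 43%
- compound 3 `CC[C@H]1COC(C)(C)C(=O)N1c1cc(-c2cc(Cl)c3c(N)ncnn23)ccc1C#N`: 1%

Among these three, compound 2 stands highest at 43%. Compound 1 is the nearest at 24%, lower by more than the usual scatter of repeated measurements. Compound 3 is the furthest at 1%, also lower by more than that scatter.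

The next compound to be tested in this assay is compound 4 `C[C@H]1CN(c2cc(-c3cc(Cl)c4c(N)ncnn34)ccc2C#N)C(=O)C(C)(C)O1`. The change from compound 2 is the two compounds have the same atoms and bonds and differ only in configuration as drawn: 1 of 1 stereo elements differ; a stereocentre at a saturated ring carbon is drawn R in compound 2 and S in compound 4. The two compounds have the same atoms and bonds and differ only in configuration as drawn: a stereocentre at a saturated ring carbon is drawn R in compound 2 and S in compound 4.

For the measured compounds named here, no two measured compounds here differ in one place only, so the data give no direct size for such a step. Compound 2 holds the top value of the three at 43%, which leaves more room for a fall than for a rise. The estimated change is a number 9 percentage points lower from compound 2 to compound 4 (within the scatter), a modest fall that would stay within the usual scatter. For compound 4 the expected value is 34%, with an estimated range from 12% to 60%.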

Compound 4, percent of the compound remaining: 0%
Estimate against measurement, compound 4: 34 percentage points above; the measured number lies below the stated range.
By their numbers in this assay, from the lowest: compounds 4 and 3 (each within the scatter of the next); then compound 1; then compound 2.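

In this assay, redrawing the one stereocentre at a saturated ring carbon from R to S gives a number 43 percentage points lower from compound 2 to compound 4 (beyond the scatter), a large step that can be assigned to configuration alone: the fact that compounds 2 and 4 differ only in the configuration as drawn. This position therefore matters in its three-dimensional arrangement, even though the two compounds share the same atoms and bonds. With the S drawing held fixed, chloro in place of trifluoromethyl on an aromatic carbon gives a number 24 percentage points lower from compound 1 to compound 4 (beyond the scatter), so the aromatic substituent also counts, and the chloro group does not guarantee a high number by itself, since compound 2 and compound 4 both carry it.

As far as these compounds go, what remains open is whether configuration has an equally large effect when trifluoromethyl sits on the aromatic carbon, as that group appears here only in the S drawing, and whether the chloro-to-trifluoromethyl step would look the same in the R drawing. It is also unknown how a methoxy group or a bromine atom on that aromatic carbon, or a hydroxymethyl group at the stereocentre, would behave in either configuration.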